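Methoxy removal on a curcumin-coumarin hybrid series

This account rests on a few compounds, and the source may have more. Where it says the series, first, only, none or still open, it means among the compounds named here.

Measured compounds:
Compound 1, `COc1ccc(/C=C/C(=O)/C=C/c2ccc(OCc3cn(CCCCCOc4cc(=O)oc5ccccc45)nn3)c(OC)c2)cc1OC`: 45%
Compound 2, `COc1cccc(/C=C/C(=O)/C=C/c2ccc(OCc3cn(CCCCCOc4cc(=O)oc5ccccc45)nn3)c(OC)c2)c1`: 36%
Compound 3, `COc1cccc(/C=C/C(=O)/C=C/c2ccc(OCc3cn(CCCCOc4cc(=O)oc5ccccc45)nn3)c(OC)c2)c1`: 44%

All three were tested in a functional assay on HCT-116 cells (Homo sapiens) for inhibition, read by sulforhodamine B assay, with a stated time of 48 h, tested at 50 uM; a higher number here means more inhibition of growth at the concentration tested, a lower number less inhibition of growth. Compound 4, `COc1cc(/C=C/C(=O)/C=C/c2ccccc2)ccc1OCc1cn(CCCCOc2cc(=O)oc3ccccc23)nn1`, has not yet been measured there.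

From compound 1 to compound 2 the change is hydrogen in place of methoxy on an aromatic carbon, and it gave a number 9 percentage points lower from compound 1 to compound 2 (within the scatter). Compound 3 differs from compound 1 in its core, and that difference between the two cores is not broken down here; in this assay compound 3 gives a value close to compound 1 and to compound 2, all within the scatter of one another.

Compound 4 is built from compound 3 by hydrogen in place of methoxy on an aromatic carbon. This is the same kind of change as from compound 1 to compound 2, though the surroundings differ: there the hydrogen entered ortho to a methoxy group and para to a large group, here meta to a large group. Beside that earlier step, a step of about a number 6 percentage points lower from compound 3 to compound 4 (within the scatter) is expected, resting on the small effect seen from compound 1 to compound 2. For compound 4 an estimated value of 38% is expected, between 25% and 50%.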

Compound 4, percent growth inhibition at one concentration: 34%
Beside the measured number, compound 4's estimate is 4 percentage points above it; the range from low to high includes it.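

In this assay, putting hydrogen in place of methoxy on compound 3 gave a number 10 percentage points lower from compound 3 to compound 4 (within the scatter), so this step taken alone cannot be told apart from repeat-to-repeat variation. Set beside the earlier example, the same change reads alike on the two cores: the same change on two cores in this assay, a number 9 percentage points lower (within the scatter) from compound 1 to compound 2 and a number 10 percentage points lower (within the scatter) from compound 3 to compound 4, 1 percentage points apart, within the scatter of two such steps

This agreement shows that the step had a similar size on both cores, but it does not establish a real loss of growth inhibition, since each step lies within the scatter, and two cores are too few to make a rule for the whole series.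

The compounds shown leave open whether a different group at that place on the aromatic ring, such as a hydroxy group, an amine or a carboxylic acid, would give a step beyond the scatter. They also leave open how compound 4 would respond to a longer chain in its linker.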